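Methoxy addition on two cores: antiproliferative notes

The source may report more compounds than this note shows. Statements on the series, on what has been measured and on what is new or still open speak of the compounds shown alone.

Measured so far:
Compound 1 `COc1ccc(/C=N/c2c(C#N)ncn2Cc2ccc(F)cc2)cc1OC`: 10500 nM
Compound 2 `COc1ccc(/C=N/c2c(C#N)ncn2Cc2ccc(F)cc2)c(OC)c1OC`: a limit of the assay, > 25000 nM
Compound 3 `COc1ccc(C2N=C(C(N)=O)c3ncn(-c4ccc(F)cc4)c3N2)cc1`: 1220 nM

All three values come from a functional assay on MDA-MB-231 cells (Homo sapiens) for antiproliferative activity, read by MTT assay, with a stated time of 48 h; a higher number here means a weaker inhibitor, a lower number a stronger inhibitor. The step of an at least 2.3-fold higher number from compound 1 to compound 2 (0.37 log units; beyond the scatter) follows from methoxy in place of hydrogen on an aromatic carbon; the value of compound 2 is only a limit, namely (the limit of > 25000 nM in this assay, at which 1 of the 3 values shown sits). Compound 3 has a different core, and the difference between the two cores is not broken down here. Compound 4 `COc1ccc(C2N=C(C(N)=O)c3ncn(-c4ccc(F)cc4)c3N2)cc1OC` remains to be measured in this assay; it differs from compound 3 by methoxy in place of hydrogen on an aromatic carbon. This is the same kind of change as from compound 1 to compound 2, though not the same: there the place was ortho to a large group and meta to a methoxy group, here it is meta to a large group. Compound 4 is expected to show the step of a 2.5-fold higher number from compound 3 to compound 4 (0.39 log units; beyond the scatter), placed beside the earlier one. That expectation rests on the weakening seen in an at least 2.3-fold higher number from compound 1 to compound 2 (0.37 log units; beyond the scatter) and on the value of compound 3, 1220 nM. Compound 4 is estimated at 3000 nM, between 1200 nM and 10000 nM.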

Compound 4, half-maximal inhibitory concentration: 6760 nM
For compound 4 the middle estimate is 2.3-fold (0.35 log units) below the measured one, within the range that was stated.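

In this assay the addition of methoxy in place of hydrogen on an aromatic carbon weakens the core of compound 3 as well, with a 5.5-fold higher number from compound 3 to compound 4 (0.74 log units; beyond the scatter), so the direction of the change is shared by the two pairs shown. Compound 2 gives > 25000 nM, which is a limit of the assay and not a number. The size of the step therefore does not carry over in any readable way, and two pairs with the methoxy in different places do not establish a rule for the series: the same change on two cores in this assay, an at least 2.3-fold higher number (0.37 log units; beyond the scatter) from compound 1 to compound 2 and a 5.5-fold higher number (0.74 log units; beyond the scatter) from compound 3 to compound 4; the limit leaves it open whether they differ.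

Still open, on these data alone, is how compound 4 would respond to an amine, a carboxylic acid or a longer chain such as ethoxy in the same place. Also open, as far as these compounds go, is whether either core tolerates any substituent there.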